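The compounds below may be only part of what the source reports. "The series", "measured", "known", "first", "only" and "open" are said of these compounds alone.

Compound 1 `COc1ccc(CNc2nc3cc(N)cc(N)c3nc2-c2ccccc2)cc1OC`: < 100000 nM, a limit
Compound 2 `CCOC(=O)[C@H](CCC(=O)O)NC(=O)c1ccc(Oc2nc3cc(N)cc(N)c3nc2-c2ccccc2)cc1`: < 100000 nM, a limit
Compound 3 `COc1ccc(Sc2nc3cc(N)cc(N)c3nc2-c2ccccc2)cc1`: < 100000 nM, a limit

All three measured compounds share the core of compound 1, which is seen in its structure above, and all three were tested in a functional assay on SK-OV-3 cells (Homo sapiens) for inhibition, read by sulforhodamine B assay, with a stated time of 48 h; a lower number here means that less compound is tolerated, a higher number that more compound is tolerated. Each of the three values is a limit of the assay rather than a number, so none of them can be placed against another. Compound 3 stands at < 100000 nM, which is a limit. The same is true of the others: the limit of < 100000 nM in this assay, at which 3 of the 3 values shown sit. Among the compounds with values here, nothing in these values separates compound 3 from compound 1 or compound 2, and no step between measured compounds can be read from them.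

Compound 4 `Nc1cc(N)c2nc(-c3ccccc3)c(Sc3ccc(F)cc3)nc2c1` is not yet measured. It differs from compound 3 in one place: fluoro in place of methoxy on an aromatic carbon. Within the data shown here, no measured step of this kind is available, and the value of compound 3 is itself a limit, so the size of the step from compound 3 to compound 4 can only be expected, not derived. Compound 4 is estimated at 40000 nM, with a range from 5000 nM to 100000 nM. The expected step, in this assay, is a step that the limit leaves unreadable from compound 3 to compound 4, with the chance that compound 4 too returns only a limit rated high.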

Compound 4, concentration lethal to 50% of the cells: 63100 nM
Compound 4: middle estimate off by 1.6-fold (0.20 log units), on the low side, and the stated range covers the measured number.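

Compound 3 gives < 100000 nM in this assay, which is a limit and not a number. Within the data shown here, compound 4 has a measured value, but no step can be read from compound 3 to compound 4, because the only value for compound 3 is a limit: the limit of < 100000 nM in this assay, at which 3 of the 4 values shown sit. The compounds shown leave open what fluoro in place of methoxy on an aromatic carbon does to the value in this assay.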